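Benzyl for pyridyl: what the cell assay should show

A few compounds are considered here, and "the series" means these few. Any claim that something is new, unique, unknown or untested is made for them only; others in the source may bear on it.

Compound 1 `COc1cccc(OC)c1C(=O)Nc1c[nH]nc1C(=O)Nc1ccncc1` was tested in an ADME assay on MRC5 cells (Homo sapiens) for inhibition, with a stated time of 72 h; on this read-out lower numbers stand for an effect already at smaller amounts and higher numbers for an effect only at larger amounts of compound. In this assay compound 1 gives > 50000 nM, which is a limit of the assay rather than a number. Compound 2 `CO[C@H]1CC[C@H](NC(=O)c2n[nH]cc2NC(=O)c2ccc(N3CCCC3)cc2)CC1` also reaches only a limit in this assay, namely > 50000 nM. Compound 3 `CO[C@H]1CC[C@H](NC(=O)c2n[nH]cc2NC(=O)c2ccccc2C(F)(F)F)CC1` gives 3300 nM in this assay. Compound 1 stands at the limit of > 50000 nM in this assay, at which 2 of the 3 values shown sit. Among the compounds with values here, no step between measured compounds that differ in one place is available to gauge the change. Compound 4 `COc1cccc(OC)c1C(=O)Nc1c[nH]nc1C(=O)NCc1ccccc1` differs from compound 1 by benzyl in place of pyridin-4-yl on an amide-type nitrogen. For this change the author expects no step beyond the scatter and estimates an at least 1.1-fold lower number from compound 1 to compound 4 (0.04 log units; that floor lies within the scatter) in this assay. Compound 4 is expected to give 45000 nM, with a range from 10000 nM to 60000 nM, most likely again as a limit only.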

Compound 4, half-maximal effective concentration: 50000 nM
Estimate against measurement, compound 4: 1.1-fold (0.05 log units) below; the range from low to high includes it.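

With benzyl in place of pyridin-4-yl on an amide-type nitrogen, compound 4 gives a number in this assay, 50000 nM. The change gives a number no higher from compound 1 to compound 4 (the limit leaves the size open). Compound 1 has only a limit, > 50000 nM, so the size of the step cannot be read. The change therefore shows no readable gain at this position, and the result stays at the edge of the assay: the limit of > 50000 nM in this assay, at which 2 of the 4 values shown sit.

On these data alone, whether a longer chain ending in an amine or a carboxylic acid on this nitrogen would lower the number stays open. So does whether benzyl would give the same result on another core.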